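The source may report more compounds than this note shows. Statements on the series, on what has been measured and on what is new or still open speak of the compounds shown alone.

Three members of the series have been run in a functional assay on SW480 cells (Homo sapiens) for cytotoxicity, read by MTT assay, with a stated time of 48 h; on this read-out higher numbers stand for weaker inhibition and lower numbers for stronger inhibition. Compound 1 `O=c1ccoc2cc(OCc3cn(Cc4ccc(Cl)cc4Cl)nn3)ccc12` returns only the limit > 100000 nM in this assay. Compound 2 `O=c1ccoc2cc(OCc3cn(Cc4cccc(F)c4)nn3)ccc12` likewise sits at the limit, > 100000 nM in this assay. Going by the values given here, compound 3 `O=c1ccoc2cc(OCc3cn(Cc4cccc(Cl)c4)nn3)ccc12` is the one member with a number, giving 12900 nM in this assay. Among the compounds with values here, the two steps into it are an at least 7.7-fold lower number from compound 1 to compound 3 (0.88 log units; beyond the scatter) and an at least 7.7-fold lower number from compound 2 to compound 3 (0.88 log units; beyond the scatter); both end at the single readable value and both start from the limit of > 100000 nM in this assay, at which 2 of the 3 values shown sit, so their true size is open-ended. Compound 4 `O=c1ccoc2cc(OCc3cn(Cc4cccc([N+](=O)[O-])c4)nn3)ccc12` keeps the core of compound 3 and differs by nitro in place of chloro on an aromatic carbon. Within the data shown here, no measured step exchanges a chloro for a nitro; the one substituent swap at that carbon is the chloro-for-fluoro step already cited, which points away from the limit but says nothing about nitro. Among the measured compounds shown here, with no step bearing directly on the change, the expectation for compound 4 in this assay is a 2.3-fold higher number from compound 3 to compound 4 (0.37 log units; beyond the scatter), a drift that may not clear the scatter. Compound 4 is expected to give 30000 nM, within 8000 nM to 100000 nM, with a fair chance that this assay reports only a limit.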

Compound 4, half-maximal inhibitory concentration: > 100000 nM
Compound 4 ended at the assay's limit; the forecaster's own chance of this, stated with the estimate: 40%; middle value at least 3.3-fold (0.52 log units) away from the limit.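

In this assay, the exchange of chloro for nitro is an at least 7.7-fold higher number from compound 3 to compound 4 (0.88 log units; beyond the scatter), so on this aromatic carbon, meta to a large group, the readable value of compound 3 is not kept with nitro. Among the compounds that differ only at this carbon, chloro in compound 3 now stands apart from both fluoro in compound 2 and nitro in compound 4, which shows that the chloro-for-fluoro gain does not extend to nitro. The steps between compounds 1, 2 and 4 cannot be read, as both ends of each are limits: the limit of > 100000 nM in this assay, at which 3 of the 4 values shown sit.

As far as these compounds go, whether bromo, methoxy or an amine on this carbon would return a number stays open. From the compounds shown here alone, the true size of the step to compound 4 also stays open, since only its lower bound can be read.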